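The compounds below may be only part of what the source reports. "The series", "measured", "known", "first", "only" and "open" are said of these compounds alone.

Going by the values given here, compound 2 `Cc1ccc(CNC(=O)CC2c3ccccc3N=C(N3CCN(CCN(C)C)CC3)N2c2ccc(-c3ccccc3)cc2)cc1` stands at the higher of the two numbers measured so far in a functional assay on SK-OV-3 cells (Homo sapiens) for cytotoxicity, read by MTT assay, with a stated time of 48 h (on this read-out higher numbers stand for weaker inhibition and lower numbers for stronger inhibition), where compound 2 gives 2330 nM; its only neighbour is compound 1 `CN(C)CCN1CCN(C2=Nc3ccccc3C(CC(=O)NCc3ccccc3)N2c2ccc(-c3ccccc3)cc2)CC1`, which in this assay gives 1970 nM, the two lying within the scatter of each other. Compound 3 `CN(C)CCN1CCN(C2=Nc3ccccc3C(CC(=O)NCc3ccc(F)cc3)N2c2ccc(-c3ccccc3)cc2)CC1` differs from compound 2 by fluoro in place of methyl on an aromatic carbon. Among the compounds with values here, the one measured change at this aromatic carbon, a 1.2-fold higher number from compound 1 to compound 2 (0.07 log units; within the scatter), stayed within the scatter, so no shift beyond the scatter is expected here either. Compound 3 is therefore estimated at 2200 nM, with a range of 1000 nM to 4800 nM. The expected step is a 1.1-fold lower number from compound 2 to compound 3 (0.02 log units; within the scatter).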

Compound 3, half-maximal inhibitory concentration: 3090 nM
Compound 3: the middle estimate sits 1.4-fold (0.15 log units) below what was measured; measured number inside the range.
By their numbers in this assay, from the lowest: compounds 1, 2 and 3 (each within the scatter of the next).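

In this assay, fluoro on this aromatic carbon, para to a large group, stays as close to methyl (a 1.3-fold higher number from compound 2 to compound 3 (0.12 log units; within the scatter)) as to hydrogen (a 1.6-fold higher number from compound 1 to compound 3 (0.20 log units; within the scatter)). With hydrogen, methyl and fluoro all within the scatter of one another, this position has now taken a halogen as well as a small carbon group with no shift that can be read. Nothing measured bears on why these values lie so close. The compounds shown leave open whether a larger or charged group here, such as an amine or a carboxylic acid, would move the number beyond the scatter.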